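The source may report more compounds than this note shows. Statements on the series, on what has been measured and on what is new or still open speak of the compounds shown alone.

Measured so far:
Compound 1, `CCNC(=O)c1cc(Oc2ccc(NC(=O)c3cc4cccnc4n(-c4ccc(F)cc4)c3=O)cc2)ccn1`, gives 190 nM in a functional assay on HT-29 cells (Homo sapiens) for antiproliferative activity, read by MTT assay, with a stated time of 72 h; on this read-out lower numbers stand for stronger inhibition and higher numbers for weaker inhibition.
Compound 2, `CCCNC(=O)c1cc(Oc2ccc(NC(=O)c3cc4cccnc4n(-c4ccccc4)c3=O)cc2)ccn1`, gives 98 nM in this assay.

Compound 2 has the lower of the two numbers, but its nearest neighbour, compound 1, sits only slightly higher, and that gap lies within the scatter of repeated measurements, so the two cannot be told apart on these data. Compound 1 and compound 2 differ in two places at once, so their comparison says nothing about either change on its own.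

Compound 3, `CCCNC(=O)c1cc(Oc2ccc(NC(=O)c3cc4cccnc4n(-c4ccc(F)cc4)c3=O)cc2)ccn1`, is built from compound 2 by a single change: fluoro in place of hydrogen on an aromatic carbon. In words, a hydrogen on the ring that carries no other substituent is replaced by fluoro, so that the phenyl becomes a 4-fluorophenyl. Among the compounds with values here, no measured pair here isolates this change. A single fluorine is a small addition, and compound 1, which already carries that 4-fluorophenyl, gives a number within the scatter of compound 2. The expectation is therefore a step in this assay of no size beyond the scatter, in either direction.

Compound 3 is expected to give about 110 nM, with a range from 50 nM to 250 nM. That estimate means a 1.1-fold higher number from compound 2 to compound 3 (0.05 log units; within the scatter), a step expected to remain within the usual scatter.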

Compound 3, half-maximal inhibitory concentration: 84 nM
Compound 3: the middle estimate sits 1.3-fold (0.12 log units) above what was measured; the range from low to high includes it.
By their numbers in this assay, from the lowest: compounds 3, 2 and 1 (each within the scatter of the next, the first and the last beyond it).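

In this assay, fluoro in place of hydrogen on the aromatic ring, which turns the phenyl into a 4-fluorophenyl, gives a 1.2-fold lower number from compound 2 to compound 3 (0.07 log units; within the scatter), so this single change on the propyl amide has no effect that can be told from repeat-measurement noise. Within the data shown here, the chain on the amide can now be read on its own for the first time: with the 4-fluorophenyl held fixed, methyl in place of hydrogen on a saturated chain carbon, two bonds along the chain from the amide-type nitrogen, turns the ethyl amide into the propyl amide and gives a 2.3-fold lower number from compound 1 to compound 3 (0.35 log units; beyond the scatter), a modest step beyond the scatter. Nothing measured here gives a reason for either step.

From the compounds shown here alone, each change rests on a single pair of compounds, so it remains open whether the fluoro result would hold on the ethyl amide, or whether the methyl step would hold on the phenyl compounds. Going by these compounds, it is also open how the number would move with chloro or methoxy in place of the fluoro, or with a butyl chain on the amide.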